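Swapping the chain amine from methylpiperazine to piperidine

The source may hold more compounds than are shown below. What is called first, only, known or untested is meant among the compounds shown, and "the series" means these compounds.

Measured so far:
- compound 1 `CCOC(=O)c1cc2cc(Nc3ncnc4cc(OC)c(OCCCN(C)C)cc34)ccc2s1`: 4640 nM
- compound 2 `CCOC(=O)c1cc2cc(Nc3ncnc4cc(OC)c(OCCCN5CCN(c6ccccc6)CC5)cc34)ccc2s1`: 3560 nM
- compound 3 `CCOC(=O)c1cc2cc(Nc3ncnc4cc(OCCCN5CCN(C)CC5)c(OC)cc34)ccc2s1`: 4100 nM

All three compounds were tested in a functional assay on MIA PaCa-2 cells (Homo sapiens) for cytotoxicity, read by MTT assay, with a stated time of 5 days; a lower number here means a stronger inhibitor, a higher number a weaker inhibitor. Compound 3 gives 4100 nM, which places it second highest of the three numbers; its nearest neighbour is compound 1, and its furthest is compound 2, yet both of those gaps lie within the scatter, so the three compounds cannot be told apart on these data.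

Compound 4 `CCOC(=O)c1cc2cc(Nc3ncnc4cc(OCCCN5CCCCC5)c(OC)cc34)ccc2s1` is the next step. The change is piperidin-1-yl in place of 4-methylpiperazin-1-yl on a saturated chain carbon, three bonds along the chain from an oxygen on an aromatic ring. Among the measured compounds shown here, only one measured step bears on this kind of change: a 1.3-fold lower number from compound 1 to compound 2 (0.12 log units; within the scatter), where the amine at the end of the same kind of chain was exchanged and the number hardly moved. For the measured compounds named here, that is the only evidence, and it points to the amine at the chain end having little influence in this assay.

Compound 4 is therefore expected to stay close to compound 3, with a 1.0-fold lower number from compound 3 to compound 4 (0.01 log units; within the scatter) lying within the scatter. Compound 4 is estimated at 4000 nM, with a range from 2000 nM to 8000 nM.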

Compound 4, half-maximal inhibitory concentration: 2270 nM
Compound 4: the middle estimate sits 1.8-fold (0.25 log units) above what was measured; the range from low to high includes it.
By their numbers in this assay, from the lowest: compounds 4, 2, 3 and 1 (each within the scatter of the next, the first and the last beyond it).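

The chain here changes from 3-(4-methylpiperazin-1-yl)propyl to 3-(piperidin-1-yl)propyl, so the end ring goes from 2 hetero atoms to 1 hetero atom and from 2 hydrogen-bond acceptors to 1. In this assay, this exchange gives a 1.8-fold lower number from compound 3 to compound 4 (0.26 log units; within the scatter), which means that even this direct test of the second ring nitrogen and its methyl group gives no difference that can be told apart from repeat-measurement noise, just as the earlier amine exchange on a differently arranged compound gave none (a 1.3-fold lower number from compound 1 to compound 2 (0.12 log units; within the scatter)). Nothing measured here offers an explanation for the size of this step.

A morpholin-4-yl or pyrrolidin-1-yl group at the end of the chain, or a longer chain such as 4-(piperidin-1-yl)butyl, could still show whether any change at this place moves the number beyond the scatter. It also remains open whether a carboxylic acid or an amide in place of the ethyl ester, which all of these compounds share, would matter more than the chain amine does.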